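The source may report more compounds than this note shows. Statements on the series, on what has been measured and on what is new or still open speak of the compounds shown alone.

Measured so far in a functional assay on HCT-116 cells (Homo sapiens) for antiproliferative activity, read by MTT assay; on this read-out higher numbers stand for weaker inhibition and lower numbers for stronger inhibition:
compound 1 `Cn1c(=O)c(=O)n(C2CCCC2)c2nc(N/N=C/c3ccc(F)c(Cl)c3)ncc21`: 9020 nM
compound 2 `Cc1cc(C)c(/C=N/Nc2ncc3c(n2)n(C2CCCC2)c(=O)c(=O)n3C)c(C)c1`: 7920 nM

Among the measured compounds shown here, compound 2 holds the lower of the two numbers, its only neighbour being compound 1, which lies within the scatter of it. The two differ only in the ring carried on a carbon with a double bond to nitrogen, and that step, a 1.1-fold lower number from compound 1 to compound 2 (0.06 log units; within the scatter), stayed within the scatter. Compound 3 `Cn1c(=O)c(=O)n(C2CCCC2)c2nc(N/N=C/c3cccc([N+](=O)[O-])c3)ncc21` is an unmeasured member of the same series; its change from compound 2 is 3-nitrophenyl in place of 2,4,6-trimethylphenyl on a carbon with a double bond to nitrogen. For the measured compounds named here, the one measured step bearing on this position exchanged one ring for another at the same carbon without moving the number beyond the scatter, so the present exchange is expected to give no step beyond the scatter in this assay either, in no set direction. Compound 3 is accordingly estimated near 8000 nM, within 3000 nM to 22000 nM. The expected step is a 1.0-fold higher number from compound 2 to compound 3 (0.00 log units; within the scatter).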

Compound 3, half-maximal inhibitory concentration: 15200 nM
Beside the measured number, compound 3's estimate is 1.9-fold (0.28 log units) below it; the range from low to high includes it.
By their numbers in this assay, from the lowest: compounds 2, 1 and 3 (each within the scatter of the next).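

In this assay, the carbon with a double bond to nitrogen now carries a third ring, and 3-nitrophenyl remains within the scatter of both earlier rings: a 1.9-fold higher number from compound 2 to compound 3 (0.28 log units; within the scatter), and a 1.7-fold higher number from compound 1 to compound 3 (0.23 log units; within the scatter). Methyl, halogen and nitro substitution on a six-membered aromatic ring of carbon therefore give no separation at this place, even though 3-nitrophenyl enters with hydrogen-bond acceptors and 2,4,6-trimethylphenyl has none. No supporting measurement accounts for these numbers.

On these data alone, whether a ring bearing an amine or a carboxylic acid, or a longer alkyl chain in place of the ring, would give a step beyond the scatter remains open. Also open, as far as these compounds go, is whether 4-nitrophenyl would read the same as 3-nitrophenyl at this carbon.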